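A few compounds are considered here, and "the series" means these few. Any claim that something is new, unique, unknown or untested is made for them only; others in the source may bear on it.

In a physicochemical assay for solubility, read by HPLC, using the shake flask method, in phosphate buffer, measured as kinetic solubility, with a stated time of 20 h, at pH 6.5 (on this read-out lower numbers stand for lower solubility and higher numbers for higher solubility), compound 1 `O=C(c1ccnc(Nc2nc3cnc(Nc4ccc(F)c(F)c4)cc3[nH]2)c1)N1CCN(C2CC2)CC1` gives < 5000 nM, which is a limit, not a number. Compound 3 `C[C@@H]1CN(C(=O)c2ccnc(Nc3nc4cnc(Nc5ccc(F)c(F)c5)cc4[nH]3)c2)C[C@H](C)O1` gives < 5000 nM, again a limit. Among the measured compounds shown here, compound 2 `C[C@@H]1CN(C(=O)c2ccnc(Nc3nc4cnc(Nc5ccc(F)c(F)c5)cc4[nH]3)c2)C[C@H](C)N1` gives the only true number, 100000 nM. This leaves (the limit of < 5000 nM in this assay, at which 2 of the 3 values shown sit). Compound 4 `O=C(c1ccnc(Nc2nc3cnc(Nc4ccc(F)c(F)c4)cc3[nH]2)c1)N1CCC(F)(F)CC1` changes the group on the carbonyl carbon: 4,4-difluoropiperidin-1-yl in place of 2,6-dimethylmorpholin-4-yl on a carbonyl carbon. For the measured compounds named here, no measured step makes this exchange. The nearest ones are large for an at least 20-fold higher number from compound 1 to compound 2 (1.30 log units; beyond the scatter) and an at least 20-fold lower number from compound 2 to compound 3 (1.30 log units; beyond the scatter), and both involve compound 2, while a step that the two limits leave unreadable from compound 1 to compound 3 cannot be read. Compound 4 is therefore expected to stay close to compound 3, with no clear direction. The expected change is a step that the limit leaves unreadable from compound 3 to compound 4. Compound 4 is estimated at 3000 nM, with an expected range from 1000 nM to 9000 nM.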

Compound 4, solubility: < 5000 nM
Compound 4: a limit, no number (the forecaster's own chance of this, stated with the estimate: 80%); the middle value is on the limit's open side.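

Compound 4, with 4,4-difluoropiperidin-1-yl on the carbonyl carbon, gives < 5000 nM, which is a limit and not a number. In this assay, replacing 3,5-dimethylpiperazin-1-yl with this fluorinated ring gives an at least 20-fold lower number from compound 2 to compound 4 (1.30 log units; beyond the scatter). The steps among compound 1, compound 3 and compound 4 cannot be read, and one limit now holds most of the values: the limit of < 5000 nM in this assay, at which 3 of the 4 values shown sit.

As far as these compounds go, only compound 2 gives a true number, so what sets 3,5-dimethylpiperazin-1-yl apart remains open. An unsubstituted piperazin-1-yl on the same carbonyl carbon could show whether the two methyl groups matter.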